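A few compounds are considered here, and "the series" means these few. Any claim that something is new, unique, unknown or untested is made for them only; others in the source may bear on it.

Compound 1, `CCOC(=O)C1=Cc2ccccc2OC1(OCc1cn(-c2ccc(C)cc2)nn1)C(F)(F)F`, is the reference point of this account. Among the measured compounds shown here, in a functional assay on A549 cells (Homo sapiens) for inhibition, read by MTT assay, with a stated time of 24 h (a lower number here means a stronger inhibitor, a higher number a weaker inhibitor), compound 1 gives 19700 nM, and it is the only compound here with a number rather than a limit. Compound 2, `CCOC(=O)C1=Cc2ccccc2OC1(OCc1cc(-c2ccc(C)cc2)no1)C(F)(F)F`, is its isomeric partner in which the triazole has become an isoxazole. In this assay compound 2 gives > 150000 nM, which is a limit of the assay and not a number, as shown by the limit of > 150000 nM in this assay, at which 1 of the 2 values shown sits. For the measured compounds named here, no step between two measured compounds can therefore be given.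

The piece follows the change from compound 1 to compound 3, `CCOC(=O)C1=Cc2ccccc2OC1(OCc1cn(-c2ccc([N+](=O)[O-])cc2)nn1)C(F)(F)F`. The difference, counted from the two structures, is nitro in place of methyl on an aromatic carbon. Going by the values given here, nothing among the measured compounds shows how such a swap plays out in this assay, so the expectation rests on the unchanged core and linker alone. The step from compound 1 to compound 3 is expected to be a 1.5-fold lower number from compound 1 to compound 3 (0.18 log units; within the scatter), that is, a shift that may not exceed the usual scatter. Compound 3 is accordingly estimated at 13000 nM, with a range from 4000 nM to 45000 nM.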

Compound 3, half-maximal inhibitory concentration: > 150000 nM
Compound 3: a limit, no number; the forecaster's own chance of this, stated with the estimate: 10%; middle value at least 11-fold (1.06 log units) from the limit.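

Compound 3 gives > 150000 nM in this assay, which is a limit of the assay and not a number. Until this point the only change shown was the isoxazole for the triazole, and this result is the first to speak to the group on the aromatic ring: nitro in place of methyl gives an at least 7.6-fold higher number from compound 1 to compound 3 (0.88 log units; beyond the scatter), so in this assay the place para to a large group is not indifferent to what it carries. Only the least size of this step can be read, and its full size stays unknown: the limit of > 150000 nM in this assay, at which 2 of the 3 values shown sit.

The compounds shown leave open whether the methyl of compound 1 adds anything at all, which a plain phenyl ring would test, and whether an amine, a methoxy group or a chlorine at the same place would fall on the stronger or the weaker side of compound 1. They also leave compound 2 and compound 3 without any order between them, and they do not tell whether a change at this place would play out the same way with the isoxazole in the molecule.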